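A few compounds are considered here, and "the series" means these few. Any claim that something is new, unique, unknown or untested is made for them only; others in the source may bear on it.

Of the compounds shown here, two have been measured so far. Compound 1 `CC(C)=CCC1Cc2c(O)cc(=O)n(CCCO)c2CC1(C)C` carries a free hydroxyl on its aromatic ring, and compound 2 `CC(C)=CCC1Cc2c(OCCCNC(=O)c3cccs3)cc(=O)n(CCCO)c2CC1(C)C` carries a 3-(((thiophen-2-yl)carbonyl)amino)propyl group on that same oxygen. In a functional assay on PANC-1 cells (Homo sapiens) for inhibition, read by MTT assay, with a stated time of 24 h, tested at 10 uM (on this read-out lower numbers stand for less inhibition and higher numbers for more inhibition at the one concentration tested (going by the name of the read-out)), compound 1 gives 0%, and in the same test compound 2 gives 5.6%. Among the measured compounds shown here, the only measured step, a number 5.6 percentage points higher from compound 1 to compound 2 (within the scatter), is therefore a change that does not rise above the noise of the measurement. Compound 2 stands highest of the two numbers, yet its nearest neighbour, compound 1, lies within the scatter of it, so no order between the two can be read.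

Compound 3 `COc1cccc(NC(=O)Oc2cc(=O)n(CCCO)c3c2CC(CC=C(C)C)C(C)(C)C3)c1` is the next candidate. It differs from compound 2 by (3-methoxyphenyl)carbamoyl in place of 3-(((thiophen-2-yl)carbonyl)amino)propyl on an oxygen on an aromatic ring. The step from compound 1 to compound 2 is the one that bears on this: it also altered the group on that oxygen and produced no shift beyond the scatter. The expected step is a number 0.6 percentage points lower from compound 2 to compound 3 (within the scatter), with no movement beyond the scatter. Compound 3 is estimated at 5%, ranging from 0% to 15%.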

Compound 3, a percentage reported as inhibition, at one concentration (the size of the read-out at that concentration, not a potency): 0%
Estimate against measurement, compound 3: 5 percentage points above; measured number inside the range.
By their numbers in this assay, from the lowest: compounds 1, 3 and 2 (each within the scatter of the next).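

In this assay, (3-methoxyphenyl)carbamoyl in place of 3-(((thiophen-2-yl)carbonyl)amino)propyl on the oxygen gives a number 5.6 percentage points lower from compound 2 to compound 3 (within the scatter), and the same group in place of hydrogen gives no change at the digits printed from compound 1 to compound 3 (within the scatter). The oxygen on the aromatic ring has now carried a hydrogen and two quite different groups, one with a five-membered aromatic ring holding a hetero atom and one with a six-membered aromatic ring of carbon only, and none of these swaps moves the read-out beyond the scatter. No outside information on these compounds is available to account for this result.

These three compounds therefore set no order among themselves and do not show whether anything placed on this oxygen can change the read-out. From the compounds shown here alone, it remains open whether a different group there, such as a chain ending in an amine or a carboxylic acid, would give a step beyond the scatter, and whether a change elsewhere on the shared core would do so.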